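The source may hold more compounds than are shown below. What is called first, only, known or untested is meant among the compounds shown, and "the series" means these compounds.

Three compounds sharing one core were measured in an assay on CHO-K1 cells for displacement of a labelled ligand from prostaglandin E2 receptor EP1 subtype (Homo sapiens); a higher number here means a weaker inhibitor, a lower number a stronger inhibitor:

Compound 1 `Cc1cc(C(=O)Nc2cccc(F)c2)nn1Cc1cc(Cl)ccc1OCc1ccccc1`: 200 nM
Compound 2 `Cc1cc(C(=O)Nc2ccc(F)cc2)nn1Cc1cc(Cl)ccc1OCc1ccccc1`: 79.4 nM
Compound 3 `Cc1cc(C(=O)Nc2ccccn2)nn1Cc1cc(Cl)ccc1OCc1ccccc1`: 126 nM

Compound 3 has the second highest number of the three. Its nearest neighbour is compound 2, a 1.6-fold higher number from compound 2 to compound 3 (0.20 log units; within the scatter); its furthest is compound 1, a 1.6-fold lower number from compound 1 to compound 3 (0.20 log units; within the scatter). Both of those steps sit within the scatter, so compound 3 cannot be separated from either. Within the data shown here, the only step beyond the scatter is a 2.5-fold lower number from compound 1 to compound 2 (0.40 log units; beyond the scatter), a modest one.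

Compound 4 `Cc1cc(C(=O)NCc2cccnc2)nn1Cc1cc(Cl)ccc1OCc1ccccc1` differs from compound 3 in one place: (pyridin-3-yl)methyl in place of pyridin-2-yl on an amide-type nitrogen. Among the measured compounds shown here, all three measured steps exchange one aromatic ring for another directly on the amide-type nitrogen; none inserts a methylene between that nitrogen and the ring, so no measured step bears on this change directly. What the measured steps do show is that swapping rings on this nitrogen moves this assay little. Since the change here is of a different kind, the expectation is wider: a step toward a somewhat higher number is expected, a 2.0-fold higher number from compound 3 to compound 4 (0.30 log units; within the scatter), though it could well stay within the scatter. Compound 4 is therefore estimated at 250 nM, in a range from 80 nM to 800 nM.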

Compound 4, half-maximal inhibitory concentration: 50.1 nM
For compound 4 the middle estimate is 5.0-fold (0.70 log units) above the measured one, and the stated range ends above it.
By their numbers in this assay, from the lowest: compounds 4, 2, 3 and 1 (each within the scatter of the next, the first and the last beyond it).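

In this assay, among these compounds, putting (pyridin-3-yl)methyl in place of pyridin-2-yl on the amide-type nitrogen gives a step beyond the scatter (a 2.5-fold lower number from compound 3 to compound 4 (0.40 log units; beyond the scatter)), showing that this position accepts a methylene ahead of the ring, whereas the earlier compounds carried their rings directly on that nitrogen. Compound 4 cannot be separated from the 4-fluorophenyl amide (a 1.6-fold lower number from compound 2 to compound 4 (0.20 log units; within the scatter)), but it stands clearly apart from the 3-fluorophenyl amide (a 4.0-fold lower number from compound 1 to compound 4 (0.60 log units; beyond the scatter)), the widest gap among the four compounds, so the gain over compound 3 does not place the new group beyond the best of the directly attached rings. Nothing available accounts for these steps.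

The step from compound 3 to compound 4 alters both the methylene and the place of the ring nitrogen, so the compounds shown leave open which of the two carries the change, a question that pyridin-3-yl or (pyridin-2-yl)methyl on the same nitrogen would address. They also leave open whether the ring nitrogen matters at all once the methylene is present, as a benzyl group would show, and whether a longer chain such as 2-(pyridin-3-yl)ethyl would be accepted.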